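Indole attachment shift in the sulfonyl pyridopyrimidinone series

A few compounds are considered here, and "the series" means these few. Any claim that something is new, unique, unknown or untested is made for them only; others in the source may bear on it.

Measured so far:
compound 1, `Cn1c(=O)c(S(=O)(=O)c2ccc(F)cc2F)cc2cnc(Nc3cccc4[nH]ccc34)nc21`, 1500 nM
compound 2, `Cn1c(=O)c(S(=O)(=O)c2ccc(Cl)cc2)cc2cnc(Nc3cccc4[nH]ccc34)nc21`, 5000 nM

Both compounds were run in a functional assay on K562 cells (Homo sapiens) for inhibition, read by trypan blue exclusion, with a stated time of 72 h; a lower number here means a stronger inhibitor, a higher number a weaker inhibitor. Compound 1 gives the lowest of the two numbers; its nearest neighbour is compound 2, and the change between them is a 3.3-fold higher number from compound 1 to compound 2 (0.52 log units; beyond the scatter), which is a change of the aryl group on the sulfonyl sulfur, not of the amine substituent.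

Compound 3, `Cn1c(=O)c(S(=O)(=O)c2ccc(F)cc2F)cc2cnc(Nc3ccc4cc[nH]c4c3)nc21`, is not yet measured. It keeps the sulfonyl aryl of compound 1 and differs from it in one place: 1H-indol-6-yl in place of 1H-indol-4-yl on a nitrogen on an aromatic ring.

Among the compounds with values here, no measured step touches the indole attachment point, so the step from compound 1 to compound 2 does not bear on this change and gives no direction for it. The shared core and every other group are unchanged. With nothing to anchor the expectation, the estimate for compound 3 is placed near compound 1 with a wide range, leaning slightly toward a higher number: compound 3 is expected to give 2500 nM in this assay, between 600 nM and 10000 nM, which corresponds to an expected step of a 1.7-fold higher number from compound 1 to compound 3 (0.22 log units; within the scatter).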

Compound 3, half-maximal inhibitory concentration: 5000 nM
Compound 3: the middle estimate sits 2.0-fold (0.30 log units) below what was measured, within the range that was stated.
By their numbers in this assay, from the lowest: compound 1; then compounds 2 and 3 (each within the scatter of the next).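

In this assay, swapping 1H-indol-4-yl for 1H-indol-6-yl on the nitrogen gives a 3.3-fold higher number from compound 1 to compound 3 (0.52 log units; beyond the scatter), so the attachment point of the indole on this nitrogen affects the number even though the two groups have the same atoms and the same printed counts. Within the data shown here, this is the first reading on the amine side of the series: the earlier step changed only the aryl group on the sulfonyl sulfur, whereas here the 2,4-difluorophenyl group and the shared core stay fixed and the indole attachment alone differs. Nothing available accounts for the size or direction of this step, and the result gives no reason for the preference for 1H-indol-4-yl over 1H-indol-6-yl.

From the compounds shown here alone, whether the same step would appear with 4-chlorophenyl on the sulfonyl sulfur remains open, as the shift is read with 2,4-difluorophenyl only. Also open, going by these compounds, is how 1H-indol-5-yl, 1H-indol-7-yl, 1-methyl-1H-indol-4-yl or a plain phenyl on the same nitrogen would compare with 1H-indol-4-yl.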